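Compound 1 to compound 3: methoxy for fluoro

A few compounds are considered here, and "the series" means these few. Any claim that something is new, unique, unknown or untested is made for them only; others in the source may bear on it.

Measured in a functional assay on MCF7 cells (Homo sapiens) for antiproliferative activity, read by MTT assay, with a stated time of 48 h; on this read-out lower numbers stand for stronger inhibition and higher numbers for weaker inhibition:
- compound 1 `Fc1ccc(-c2nn(-c3ccccc3)cc2-c2nc3cc(Br)ccc3[nH]2)cc1` gives 3210 nM
- compound 2 `Cc1ccc2[nH]c(-c3cn(-c4ccccc4)nc3-c3ccc(F)cc3)nc2c1` gives 1120 nM

Among the compounds with values here, of these two numbers, the one for compound 1 is the higher. The next compound to read is compound 3 `COc1ccc(-c2nn(-c3ccccc3)cc2-c2nc3cc(Br)ccc3[nH]2)cc1`, not yet measured. Its difference from compound 1 is methoxy in place of fluoro on an aromatic carbon, which amounts to 4-fluorophenyl to 4-methoxyphenyl, para to a large group.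

Within the data shown here, only one measured step is available: a 2.9-fold lower number from compound 1 to compound 2 (0.46 log units; beyond the scatter). That modest step, methyl in place of bromo, lies beyond the scatter but occurs at a different place, so it offers only a rough scale and no direction. No step beyond the scatter is therefore expected in this assay. The expected change is a 1.1-fold lower number from compound 1 to compound 3 (0.06 log units; within the scatter). Compound 3 is estimated at 2800 nM, with an expected range of 1100 nM to 7000 nM.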

Compound 3, half-maximal inhibitory concentration: 1830 nM
Beside the measured number, compound 3's estimate is 1.5-fold (0.18 log units) above it; the measured number falls inside the stated range.
By their numbers in this assay, from the lowest: compounds 2, 3 and 1 (each within the scatter of the next, the first and the last beyond it).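

In this assay, within the data shown here, methoxy in place of fluoro on the aromatic carbon para to a large group gives a 1.8-fold lower number from compound 1 to compound 3 (0.24 log units; within the scatter), the first reading at this position, as the earlier step concerned the bromo group at a different place. With the bromo group kept, this read-out therefore does not separate 4-fluorophenyl from 4-methoxyphenyl. Nothing available bears on why the two groups read this way.

Going by these compounds, whether an amine or a carboxylic acid on this carbon would give a step beyond the scatter remains open. Also open, on these data alone, is whether 4-methoxyphenyl would read the same way with the methyl group of compound 2 in place of the bromo group.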